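Swapping tert-butoxy on a carbonyl carbon: an expected outcome

This account rests on a few compounds, and the source may have more. Where it says the series, first, only, none or still open, it means among the compounds named here.

Measured so far:
compound 1 `C=C[C@@H]1C[C@]1(NC(=O)[C@@H]1C[C@@H](Oc2nccc3cc(OC)ccc23)CN1C(=O)[C@@H](NC(=O)N[C@H](C(=O)O)C(C)(C)C)C(C)(C)C)C(=O)NS(=O)(=O)C1CC1`: 91 ng.h/mL
compound 2 `C=C[C@@H]1C[C@]1(NC(=O)[C@@H]1C[C@@H](Oc2nccc3cc(OC)ccc23)CN1C(=O)[C@@H](NC(=O)N[C@H](C(=O)N1CCN(c2ncccn2)CC1)C(C)(C)C)C(C)(C)C)C(=O)NS(=O)(=O)C1CC1`: 1630 ng.h/mL
compound 3 `C=C[C@@H]1C[C@]1(NC(=O)[C@@H]1C[C@@H](Oc2cc(-c3ccccc3)nc3cc(OC)ccc23)CN1C(=O)[C@@H](NC(=O)OC(C)(C)C)C(C)(C)C)C(=O)NS(=O)(=O)C1CC1`: 61 ng.h/mL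

All three numbers come from an ADME assay on the whole organism (plasma, Rattus norvegicus, strain Sprague-Dawley) for pharmacokinetics, read by LC-MS, with a stated time of 4 h, at a dose of 15 mg/kg by the intraduodenal route; a lower number here means less compound in the circulation, a higher number more compound in the circulation at the dose given. Compound 3 gives 61 ng.h/mL, which lies within the usual scatter of compound 1 at 91 ng.h/mL and far from compound 2 at 1630 ng.h/mL.

Compound 4 `C=C[C@@H]1C[C@]1(NC(=O)[C@@H]1C[C@@H](Oc2cc(-c3ccccc3)nc3cc(OC)ccc23)CN1C(=O)[C@@H](NC(=O)N(C)C(C)(C)C)C(C)(C)C)C(=O)NS(=O)(=O)C1CC1` differs from compound 3 in one place, with methyl(tert-butyl)amino in place of tert-butoxy on a carbonyl carbon. The carbonyl carbon stays bound to its amide-type nitrogen.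

Among the compounds with values here, only one measured step offers any guidance, an 18-fold higher number from compound 1 to compound 2 (1.25 log units; beyond the scatter). It shows that a change on a carbonyl carbon can move this number by a large amount. That step, however, put 4-(pyrimidin-2-yl)piperazin-1-yl in place of hydroxy, and neither group takes part in the change considered here. Within the data shown here, no measured step replaces tert-butoxy, so the large size of that step does not carry over, and the direction remains uncertain.

The expected result is therefore no clear shift in this assay, and the estimated step is a 1.3-fold higher number from compound 3 to compound 4 (0.12 log units; within the scatter). For compound 4 the estimate is 80 ng.h/mL, with an expected range from 20 ng.h/mL to 320 ng.h/mL.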

Compound 4, area under the concentration-time curve: 32 ng.h/mL
Beside the measured number, compound 4's estimate is 2.5-fold (0.40 log units) above it; the measured number falls inside the stated range.
By their numbers in this assay, from the lowest: compounds 4, 3 and 1 (each within the scatter of the next, the first and the last beyond it); then compound 2.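

In this assay, methyl(tert-butyl)amino in place of tert-butoxy on a carbonyl carbon gives a 1.9-fold lower number from compound 3 to compound 4 (0.28 log units; within the scatter), so this exchange cannot be told apart from no effect at all, even though tert-butoxy counts one hydrogen-bond acceptor and methyl(tert-butyl)amino none. The earlier 18-fold higher number from compound 1 to compound 2 (1.25 log units; beyond the scatter) also fell on a carbonyl carbon, but with other groups, and the new step shows that a change on such a carbon need not bring a large shift in this number. Nothing measured here explains why the number stays within the scatter for this pair of groups.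

The compounds shown leave open whether 4-(pyrimidin-2-yl)piperazin-1-yl, which accompanied the large step on the core of compound 1, would bring a similar step on the core of compound 3. They also leave open whether a simple amine such as tert-butylamino, without the methyl, or a smaller alkoxy group such as ethoxy on this carbonyl carbon would stay within the scatter of compound 3.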